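Carbamoyl(phenyl)methyl Gives Way to Pyrimidin-2-yl

This account rests on a few compounds, and the source may have more. Where it says the series, first, only, none or still open, it means among the compounds named here.

Compound 3 `NC(=O)C(c1ccccc1)N1CCN(CCCc2c[nH]c3ccc(-n4cnnc4)cc23)CC1` carries a carbamoyl(phenyl)methyl group on the ring nitrogen, and in a functional assay on CHO cells for activation of 5-hydroxytryptamine receptor 1D (Homo sapiens), read by GTPgammaS binding (a lower number here means that less compound is needed, a higher number that more compound is needed for the effect), compound 3 gives 0.2 nM, the lowest of the three numbers measured. Compound 1 `c1ccc(CN2CCN(CCCc3c[nH]c4ccc(-n5cnnc5)cc34)CC2)nc1` in this assay gives 0.3 nM, and compound 2 `c1coc(CN2CCN(CCCc3c[nH]c4ccc(-n5cnnc5)cc34)CC2)c1` in this assay gives 0.5 nM. The steps among them are small: a 1.5-fold lower number from compound 1 to compound 3 (0.18 log units; within the scatter) and a 1.7-fold higher number from compound 1 to compound 2 (0.22 log units; within the scatter) lie within the scatter, while a 2.5-fold lower number from compound 2 to compound 3 (0.40 log units; beyond the scatter) is a modest step beyond it. Compound 4 `c1cnc(N2CCN(CCCc3c[nH]c4ccc(-n5cnnc5)cc34)CC2)nc1` differs from compound 3 by pyrimidin-2-yl in place of carbamoyl(phenyl)methyl on an amine nitrogen in a ring. All three measured steps concern exchanges of the group on that same ring nitrogen, and none moved the number far; none of them, however, sets an aromatic ring directly on the nitrogen as compound 4 does. One therefore expects only a small shift, if any, and leaning toward a higher number, a 2.5-fold higher number from compound 3 to compound 4 (0.40 log units; beyond the scatter). For compound 4 in this assay the estimate is 0.5 nM, within a range from 0.15 nM to 2 nM.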

Compound 4, half-maximal effective concentration: 0.6 nM
Compound 4: the middle estimate sits 1.2-fold (0.08 log units) below what was measured, and the stated range covers the measured number.
By their numbers in this assay, from the lowest: compounds 3, 1, 2 and 4 (each within the scatter of the next, the first and the last beyond it).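

In this assay the place on the amine nitrogen in a ring accepts an aromatic ring set directly on it: a 1.2-fold higher number from compound 2 to compound 4 (0.08 log units; within the scatter) and a 2.0-fold higher number from compound 1 to compound 4 (0.30 log units; within the scatter) both stay within the scatter, so pyrimidin-2-yl cannot be told apart from (furan-2-yl)methyl or (pyridin-2-yl)methyl. Only the exchange for carbamoyl(phenyl)methyl, a 3.0-fold higher number from compound 3 to compound 4 (0.48 log units; beyond the scatter) and thus a modest step, passes beyond the scatter, and the four groups still span a narrow range. Nothing at hand bears on why this one step stands out.

The compounds shown leave open whether a plain methyl or a cyclohexyl on that nitrogen would keep the number as low. They also leave open whether a carboxylic acid in place of the carbamoyl would preserve the value of compound 3 0.2 nM in this series.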